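Changing the para substituent on compound 1's aryl ring

The source may hold more compounds than are shown below. What is called first, only, known or untested is meant among the compounds shown, and "the series" means these compounds.

Measured compounds in an assay on Sf9 cells for inhibition of protein deacetylase HDAC6 (Homo sapiens), read by fluorescence, with a stated time of 40 min, tested at 100 nM; on this read-out higher numbers stand for more inhibition at the one concentration tested (going by the name of the read-out) and lower numbers for less inhibition:
Compound 1 `COc1ccc(-c2nc(CNc3ccc(C(=O)NO)cc3)n(-c3ccccc3)n2)cc1` gives 77.6%.
Compound 2 `O=C(NO)c1ccc(NCc2nc(-c3ccccc3)nn2-c2ccc(Br)cc2)cc1` gives 65.9%.
Compound 3 `O=C(NO)c1ccc(NCc2nc(-c3ccccc3)nn2-c2cccc(Cl)c2)cc1` gives 62.3%.

Compound 1 has the highest of the three numbers; the gap to compound 2 and the gap to compound 3 both lie beyond the scatter, so compound 1 stands clearly on top here. Compound 4 `CCc1ccc(-c2nc(CNc3ccc(C(=O)NO)cc3)n(-c3ccccc3)n2)cc1` differs from compound 1 in one place: ethyl in place of methoxy on an aromatic carbon. Viewed one bond further out, the change reads 4-methoxyphenyl to 4-ethylphenyl.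

Within the data shown here, the only measured step, a number 3.6 percentage points lower from compound 2 to compound 3 (within the scatter), concerns a different ring, the one on the aromatic nitrogen, and was within the scatter. Among the measured compounds shown here, no measured pair shows what swapping a substituent on the carbon-only ring does, so there is no direct guide. Given that the one available step changed little, the expectation for compound 4 is a small shift, estimated as a number 5.6 percentage points lower from compound 1 to compound 4 (within the scatter), not clearly beyond the scatter. Compound 4 is therefore estimated at 72%, with a range from 55% to 85%.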

Compound 4, a percentage reported as inhibition, at one concentration (the size of the read-out at that concentration, not a potency): 54.6%
Beside the measured number, compound 4's estimate is 17.4 percentage points above it, and the stated range ends above it.
By their numbers in this assay, from the lowest: compounds 4, 3 and 2 (each within the scatter of the next, the first and the last beyond it); then compound 1.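

In this assay, among these compounds, the step of a number 23 percentage points lower from compound 1 to compound 4 (beyond the scatter) gives the first measured change at this place, on a six-membered aromatic ring of carbon only, para to a large group. It shows that the read-out is sensitive to what sits here: methoxy and ethyl have the same count of heavy atoms, but methoxy has an oxygen and a hydrogen-bond acceptor that ethyl lacks. No supporting measurement is available to explain the difference between these two groups.

From the compounds shown here alone, whether the oxygen is what matters stays open, and a hydroxyl, an amine or a longer chain such as propoxy at this place would help to test it. Going by these compounds, with only one concentration in this assay, how this gap would translate into potency also remains unknown.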